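Compound 4: a methoxycarbonylphenyl group replaces cyclopropyl

The source may report more compounds than this note shows. Statements on the series, on what has been measured and on what is new or still open speak of the compounds shown alone.

Three measured compounds share one core:
Compound 1 `COc1cc2cc(C(=O)CCc3cc[n+](C)cc3)sc2cc1OC` gives 3000 ug/mL in a physicochemical assay for solubility; on this read-out higher numbers stand for higher solubility and lower numbers for lower solubility.
Compound 2 `C=CC[n+]1ccc(CCC(=O)c2cc3cc(OC)c(OC)cc3s2)cc1` gives 25000 ug/mL in this assay.
Compound 3 `COc1cc2cc(C(=O)CCc3cc[n+](CC4CC4)cc3)sc2cc1OC` gives 15000 ug/mL in this assay.

Of the three numbers, compound 3 gives the second highest; the gap a 1.7-fold lower number from compound 2 to compound 3 (0.22 log units; within the scatter) lies within the scatter, whereas a 5.0-fold higher number from compound 1 to compound 3 (0.70 log units; beyond the scatter) lies beyond it. Compound 4 `COC(=O)c1ccc(C[n+]2ccc(CCC(=O)c3cc4cc(OC)c(OC)cc4s3)cc2)cc1` differs from compound 3 by 4-(methoxycarbonyl)phenyl in place of cyclopropyl on a saturated chain carbon bound to an aromatic nitrogen. Among the compounds with values here, no measured step covers this change. The nearest comparisons are an 8.3-fold higher number from compound 1 to compound 2 (0.92 log units; beyond the scatter) and a 5.0-fold higher number from compound 1 to compound 3 (0.70 log units; beyond the scatter), both modest rises after a small group replaced hydrogen at the same place. The entering group here is far larger than either of those, so a modest drop is expected, a 2.5-fold lower number from compound 3 to compound 4 (0.40 log units; beyond the scatter). Compound 4 is estimated at 6000 ug/mL, with a range from 1500 ug/mL to 25000 ug/mL.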

Compound 4, solubility: 3500 ug/mL
Compound 4: middle estimate off by 1.7-fold (0.23 log units), on the high side, and the stated range covers the measured number.
By their numbers in this assay, from the lowest: compounds 1 and 4 (each within the scatter of the next); then compounds 3 and 2 (each within the scatter of the next).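

In this assay, the rise seen with the small groups does not carry over to the larger 4-(methoxycarbonyl)phenyl group (a 4.3-fold lower number from compound 3 to compound 4 (0.63 log units; beyond the scatter); a 7.1-fold lower number from compound 2 to compound 4 (0.85 log units; beyond the scatter)). Its number instead stays within the scatter of the one with hydrogen at this place (a 1.2-fold higher number from compound 1 to compound 4 (0.07 log units; within the scatter)), so replacing that hydrogen does not by itself raise the number. Nothing shown accounts for this difference. The compounds shown leave open whether the benzene ring or the methoxycarbonyl group sets this result. A plain benzyl group or a carboxylic acid in place of the methoxycarbonyl group would separate the two.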